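Compound 3 to compound 4: benzoyl replaced by dichlorophenyl

A few compounds are considered here, and "the series" means these few. Any claim that something is new, unique, unknown or untested is made for them only; others in the source may bear on it.

Values from a functional assay on HepG2 cells (Homo sapiens) for cytotoxicity, with a stated time of 72 h (a lower number here means that less compound is needed, a higher number that more compound is needed for the effect), are limits of the assay and not numbers:
- Compound 1 `C=C[C@@](C)(/C=C/c1ccc(O)cc1)CCC=O` gives > 52000 nM as a limit
- Compound 2 `C=C[C@@](C)(/C=C/c1ccc(O)cc1)CC/C=C(\C)C(=O)OCC` gives > 52000 nM as a limit
- Compound 3 `C=C[C@@](C)(/C=C/c1ccc(O)c(/C=C/C(=O)c2ccccc2)c1)CCC=C(C)C` gives > 52000 nM as a limit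

Compound 3 gives > 52000 nM as a limit, so it offers no number to work from. Within the data shown here, the series as a whole stands at the limit of > 52000 nM in this assay, at which 3 of the 3 values shown sit, and no measured step between compounds is available.

Compound 4 `C=C[C@@](C)(/C=C/c1ccc(O)c(/C=C/c2ccc(Cl)c(Cl)c2)c1)CCC=C(C)C` has 3,4-dichlorophenyl in place of benzoyl on a double-bonded chain carbon bound to a double-bonded chain carbon when set against compound 3.

In this assay the expectation is for no step beyond the scatter, or at most a small move toward a lower number. The estimated step is an at least 1.1-fold lower number from compound 3 to compound 4 (0.06 log units; that floor lies within the scatter) and should be read as a rough expectation. The estimate for compound 4 is 45000 nM with an expected span from 15000 nM to 80000 nM around it, and a report of only a limit is the likelier outcome.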

Compound 4, half-maximal effective concentration: > 52000 nM
Compound 4 was reported as a limit; the forecaster's own chance of this, stated with the estimate: 65%; middle value at least 1.1-fold (0.06 log units) from the limit.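

Among these compounds, compound 3 and compound 4 both stand as limits in this assay, and no step between them can be read. The compounds shown leave open whether 3,4-dichlorophenyl in place of benzoyl changes anything, and at what concentration any of them would give a measurable effect in this assay.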